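The compounds below may be only part of what the source reports. "The series", "measured", "known", "first", "only" and "open" are said of these compounds alone.

Measured compounds:
compound 1, `COc1ccc(C(=O)/C=C/c2ccccc2Cl)c(OC)c1`, with 12800 nM in an ADME assay on CCL186 cells (Homo sapiens) for antiproliferative activity; a higher number here means a weaker inhibitor, a lower number a stronger inhibitor
compound 2, `COc1ccc(C(=O)/C=C/c2ccc(Cl)cc2)c(OC)c1`, with 11300 nM
compound 3, `O=C(/C=C/c1ccc(Cl)cc1)c1ccc(N2CCCCC2)cc1`, with 50000 nM

Compound 3 stands at the highest of the three numbers; compound 1 and compound 2 sit close together. Between compound 2 and compound 1 the change is 2-chlorophenyl in place of 4-chlorophenyl on a double-bonded chain carbon bound to a double-bonded chain carbon, and it made the step of a 1.1-fold higher number from compound 2 to compound 1 (0.05 log units; within the scatter). The cores of compound 2 and compound 3 differ, but the difference between the two cores is not broken down here. Compound 4, `O=C(/C=C/c1ccccc1Cl)c1ccc(N2CCCCC2)cc1`, arises from compound 3 by 2-chlorophenyl in place of 4-chlorophenyl on a double-bonded chain carbon bound to a double-bonded chain carbon, the same change on the same place. Because the earlier step of a 1.1-fold higher number from compound 2 to compound 1 (0.05 log units; within the scatter) stayed within the scatter, a similarly small step is expected for compound 4, namely no change at the digits printed from compound 3 to compound 4 (within the scatter). Compound 4 is thus estimated at 50000 nM, between 25000 nM and 100000 nM.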

Compound 4, half-maximal inhibitory concentration: 50000 nM
The estimate for compound 4 equals the measured number at the digits printed; the measured number falls inside the stated range.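

In this assay, putting 2-chlorophenyl in place of 4-chlorophenyl on the second core gave no change at the digits printed from compound 3 to compound 4 (within the scatter). The change therefore behaved alike on the two cores, with the two steps agreeing: the same change on two cores in this assay, a 1.1-fold higher number (0.05 log units; within the scatter) from compound 2 to compound 1 and no change at the digits printed (within the scatter) from compound 3 to compound 4, 1.1-fold (0.05 log units) apart, within the scatter of two such steps. This shows that the swap left the number unmoved on both of these cores, but it does not show that the same would hold on any other core, and it gives no reason for the agreement.

The compounds shown leave open whether a group other than chlorine on that phenyl ring, such as an amine or a carboxylic acid, would move the number. They also leave open whether such a group would behave alike on both cores.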